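A few compounds are considered here, and "the series" means these few. Any claim that something is new, unique, unknown or untested is made for them only; others in the source may bear on it.

Measured so far:
Compound 1, `COc1cccc(/C=C2\CCC/C(=C\c3ccc(Cl)cc3Cl)C2=O)c1OC`: > 20000 nM
Compound 2, `COc1ccc(/C=C2\CCC/C(=C\c3ccc(Cl)cc3)C2=O)cc1OC`: 4800 nM

Among the compounds with values here, in a functional assay on HT-1080 cells (Homo sapiens) for cytotoxicity, read by MTT assay, with a stated time of 72 h (on this read-out lower numbers stand for stronger inhibition and higher numbers for weaker inhibition), compound 2 gives 4800 nM, the only full number in the set. Compound 1 is reported only as a limit of the assay, > 20000 nM. That limit is the one noted as the limit of > 20000 nM in this assay, at which 1 of the 2 values shown sits, so the two values cannot be set in order beyond it. Compound 3, `COc1ccc(/C=C2\CCC/C(=C\c3ccc(Cl)cc3Cl)C2=O)cc1OC`, is built on the core of compound 2 and differs from it by chloro in place of hydrogen on an aromatic carbon; read one bond further out, 4-chlorophenyl becomes 2,4-dichlorophenyl. Within the data shown here, compound 1 carries the same 2,4-dichlorophenyl but differs elsewhere too, so no measured step covers this change. He expects a modest shift toward weaker inhibition from compound 2 to compound 3, of about a 1.7-fold higher number from compound 2 to compound 3 (0.22 log units; within the scatter), which may still sit within the scatter. His estimate for compound 3 is 8000 nM, with a range from 2500 nM to 25000 nM.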

Compound 3, half-maximal inhibitory concentration: 10500 nM
Estimate against measurement, compound 3: 1.3-fold (0.12 log units) below, and the stated range covers the measured number.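

Set on an aromatic carbon ortho to a large group and meta to a chloro group, chloro in place of hydrogen gives, in this assay, a 2.2-fold higher number from compound 2 to compound 3 (0.34 log units; beyond the scatter). Within the data shown here, this is the first step that can be read at this position, and it shows that the change from 4-chlorophenyl to 2,4-dichlorophenyl moves the number only modestly and leaves compound 3 with a full value. Compound 1, which also carries 2,4-dichlorophenyl, remains the one compound held at a limit and not a number: the limit of > 20000 nM in this assay, at which 1 of the 3 values shown sits.

The compounds shown leave open whether a fluoro, a methoxy or an amine on this same carbon would move the number in the same direction. They also leave open whether chloro in place of hydrogen would give a similar step with the two methoxy groups placed as in compound 1.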